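The compounds below may be only part of what the source reports. "The series", "measured", "known", "first", "only" and "open" are said of these compounds alone.

Measured so far in a functional assay on ECV-304 cells (Homo sapiens), with stated times of 30 min and 6 h; on this read-out lower numbers stand for an effect already at smaller amounts and higher numbers for an effect only at larger amounts of compound:
Compound 1 `Cc1nc(C)c(CN2CCN(C(=O)c3cccnc3)CC2)nc1C`, which in this assay gives 220000 nM.
Compound 2 `COc1ccc(OC)c(/C=C/C(=O)N2CCN(Cc3nc(C)c(C)nc3C)CC2)c1`, which in this assay gives 376000 nM.
Compound 3 `COc1cc(/C=C(\C(C)=O)C(=O)N2CCN(Cc3nc(C)c(C)nc3C)CC2)ccc1O`, for which the entry in this assay reads "not determined" (no result reported), so no result was reported.

Compound 1 has the lower of the two numbers, but compound 2 sits only a little higher and that gap lies within the scatter, so the two cannot be ranked. Compound 4 `CCOC(=O)N1CCN(Cc2nc(C)c(C)nc2C)CC1` differs from compound 1 by a single change: ethoxy in place of pyridin-3-yl on a carbonyl carbon. Within the data shown here, no pair of measured compounds shows a step of this kind, so there is nothing to suggest a shift in this assay beyond the scatter in either direction, and the range must stay wide. Compound 4 is therefore expected to give 250000 nM, between 80000 nM and 800000 nM. This corresponds to an expected step of a 1.1-fold higher number from compound 1 to compound 4 (0.06 log units; within the scatter).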

Compound 4, half-maximal effective concentration: 76600 nM
Compound 4: middle estimate off by 3.3-fold (0.51 log units), on the high side; the whole stated range lies above it.
By their numbers in this assay, from the lowest: compound 4; then compounds 1 and 2 (each within the scatter of the next).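

In this assay, putting ethoxy in place of pyridin-3-yl on the carbonyl carbon gives a 2.9-fold lower number from compound 1 to compound 4 (0.46 log units; beyond the scatter) and is the only readable single change among these compounds. At this position, the aromatic ring is therefore not required for the effect, and a smaller group without a ring is tolerated. Nothing measured here explains the shift. Still open, on these data alone, is whether a longer chain such as butoxy would lower the number further. Replacing ethoxy with propyl, which lacks the oxygen, would show whether that atom matters.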